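This account rests on a few compounds, and the source may have more. Where it says the series, first, only, none or still open, it means among the compounds named here.

Compounds measured in an assay on isolated protein for inhibition of Equilibrative nucleoside transporter 1 (Homo sapiens); on this read-out lower numbers stand for stronger inhibition and higher numbers for weaker inhibition:

- compound 1, `OC[C@H]1O[C@@H](n2cnc3c(SCc4ccccc4Cl)ncnc32)[C@H](O)[C@@H]1O`: 117 nM
- compound 2, `OC[C@H]1O[C@@H](n2cnc3c(SCc4ccccc4I)ncnc32)[C@H](O)[C@@H]1O`: 19.5 nM
- compound 3, `N#Cc1cccc(CSc2ncnc3c2ncn3[C@@H]2O[C@H](CO)[C@@H](O)[C@H]2O)c1`: 36.3 nM

Compound 3 stands second highest of these three numbers: its gap to compound 2 is within the scatter, while compound 1 lies beyond the scatter above it. Compound 4, `OC[C@H]1O[C@@H](n2cnc3c(SCc4ccc(Cl)c(Cl)c4)ncnc32)[C@H](O)[C@@H]1O`, has not yet been measured. It differs from compound 3 only at the group on the saturated chain carbon bound to a sulfur: 3,4-dichlorophenyl in place of 3-cyanophenyl on a saturated chain carbon bound to a sulfur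

Two measured steps change the same place. One is a 3.2-fold lower number from compound 1 to compound 3 (0.51 log units; beyond the scatter); the other is a 1.9-fold higher number from compound 2 to compound 3 (0.27 log units; within the scatter). Both show that swapping the aryl group shifts the number by a modest amount at most, with compound 2 and compound 3 indistinguishable within the scatter. The step to compound 4 is therefore expected to be small, plausibly a slightly lower number but not clearly beyond the scatter. For compound 4 the step is estimated to be a 1.5-fold lower number from compound 3 to compound 4 (0.16 log units; within the scatter). For compound 4 the expected value in this assay is 25 nM, with a likely range from 8 nM to 80 nM.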

Compound 4, inhibition constant: 12.6 nM
Beside the measured number, compound 4's estimate is 2.0-fold (0.30 log units) above it; measured number inside the range.
By their numbers in this assay, from the lowest: compounds 4, 2 and 3 (each within the scatter of the next, the first and the last beyond it); then compound 1.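

Swapping 3-cyanophenyl for 3,4-dichlorophenyl gives a 2.9-fold lower number from compound 3 to compound 4 (0.46 log units; beyond the scatter) in this assay and so shows that a change at this place can clear the scatter even when the outgoing group is not 2-chlorophenyl. Replacing 2-iodophenyl with 3,4-dichlorophenyl gives a 1.5-fold lower number from compound 2 to compound 4 (0.19 log units; within the scatter) and so leaves these two different aryl groups indistinguishable. Going by these compounds alone, replacing 2-chlorophenyl with 3,4-dichlorophenyl gives a 9.3-fold lower number from compound 1 to compound 4 (0.97 log units; beyond the scatter) as the largest step at this place so far, and compound 1 now lies beyond the scatter from all three other compounds.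

Still open, going by these compounds, is how an amine or a carboxylic acid on the aromatic ring, or a longer chain in place of the saturated chain carbon bound to a sulfur, would shift the number. Nothing measured here accounts for the differences among these aryl groups.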